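Swapping the aryl group on the five-membered ring of compound 3

A few compounds are considered here, and "the series" means these few. Any claim that something is new, unique, unknown or untested is made for them only; others in the source may bear on it.

For the measured compounds named here, compound 3 `COc1cc(C2=NN(C(C)=O)C(c3c(Cl)cccc3Cl)O2)cc(OC)c1OC` has the lowest of the three numbers so far in a functional assay on BGC-823 cells (Homo sapiens) for antiproliferative activity, read by MTT assay, tested at 1 uM (a lower number here means a weaker effect, a higher number a stronger effect of the compound at the concentration tested), giving -1.4%. Its nearest neighbour is compound 1 `COc1cc(C2=NN(C(C)=O)C(c3ccc(F)cc3)O2)cc(OC)c1OC`, which in this assay gives -0.4%; the step of a number 1 percentage points lower from compound 1 to compound 3 (within the scatter) lies within the scatter. Furthest away is compound 2 `COc1cc(C2=NN(C(C)=O)C(c3ccccc3F)O2)cc(OC)c1OC`, which gives 29.6%, so that the step of a number 31 percentage points lower from compound 2 to compound 3 (beyond the scatter) is large.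

The next compound 4 `COc1cc(C2=NN(C(C)=O)C(c3cccc(OC)c3OC)O2)cc(OC)c1OC` differs from compound 3 in one place: 2,3-dimethoxyphenyl in place of 2,6-dichlorophenyl on a saturated ring carbon

Going by the values given here, two measured steps touch the same aryl group: a number 30 percentage points higher from compound 1 to compound 2 (beyond the scatter) and a number 31 percentage points lower from compound 2 to compound 3 (beyond the scatter). Both show that changing this ring shifts the number well beyond the scatter, in either direction, and none of them involves a methoxy group, so the direction for compound 4 is open. A step of the size a number 11.4 percentage points higher from compound 3 to compound 4 (beyond the scatter) is therefore expected as a cautious middle, with a wide range. For compound 4 the value in this assay is estimated at 10%, between -10% and 40%.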

Compound 4, a percentage reported as inhibition, at one concentration (the size of the read-out at that concentration, not a potency): 3.8%
Compound 4: the middle estimate sits 6.2 percentage points above what was measured; low and high end bracket the measured number.
By their numbers in this assay, from the lowest: compounds 3, 1 and 4 (each within the scatter of the next); then compound 2.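

Among the aryl groups on this saturated ring carbon, only 2,3-dimethoxyphenyl carries hydrogen-bond acceptors, yet in this assay the change gives a number 5.2 percentage points higher from compound 3 to compound 4 (within the scatter) and a number 4.2 percentage points higher from compound 1 to compound 4 (within the scatter) and so leaves compound 4 level with these two compounds. Compound 2 remains apart from all three, and the step of a number 25.8 percentage points lower from compound 2 to compound 4 (beyond the scatter) shows that the 2-fluorophenyl group is still the only one of the four aryl groups to give a number beyond the scatter of the others. Nothing measured alongside these values accounts for this difference.

The four compounds leave open whether a single methoxy group in place of the fluorine of compound 2 would keep its number. They also leave open what an amine or a carboxylic acid on this aryl ring would do.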